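Swapping tert-butyl for cyclopropyl on a shared core

A few compounds are considered here, and "the series" means these few. Any claim that something is new, unique, unknown or untested is made for them only; others in the source may bear on it.

Measured compounds:
compound 1 `O=C(O)c1ccccc1-c1ccc(CCc2ncc(Cc3ccc(Cl)cc3)[nH]2)cc1`, which in an in vitro functional assay on cells for agonist activity at Bombesin receptor subtype-3 (Mus musculus), read by luminescence and calcium flux (on this read-out lower numbers stand for an effect already at smaller amounts and higher numbers for an effect only at larger amounts of compound), gives 102 nM
compound 2 `O=C(O)c1ccccc1-c1ccc(CCc2ncc(CCc3ccccc3)[nH]2)cc1`, which in this assay gives 174 nM
compound 3 `CC(C)(C)Cc1cnc(CCc2ccc(-c3ccccc3C(=O)O)cc2)[nH]1`, which in this assay gives 6.3 nM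

Compound 3 has the lowest number of the three. The step of a 16-fold lower number from compound 1 to compound 3 (1.21 log units; beyond the scatter) and the step of a 28-fold lower number from compound 2 to compound 3 (1.44 log units; beyond the scatter) are both large and both beyond the scatter, so compound 3 clearly stands apart from compound 1 and compound 2. The step of a 1.7-fold higher number from compound 1 to compound 2 (0.23 log units; within the scatter), by contrast, lies within the scatter.

Compound 4 `O=C(O)c1ccccc1-c1ccc(CCc2ncc(CC3CC3)[nH]2)cc1` has not yet been measured. It differs from compound 3 in one place: cyclopropyl in place of tert-butyl on a saturated chain carbon bound to an aromatic carbon.

The two large steps both bear on this change only loosely. Among the measured compounds shown here, they show that tert-butyl at this position gives a much lower number than either 4-chlorophenyl or benzyl, yet none of the measured steps compares tert-butyl with a small group such as cyclopropyl. The safest reading is that moving away from tert-butyl costs something, but less than moving to the larger groups of compound 1 and compound 2. For compound 4 a moderately higher number in this assay is therefore expected, an estimated step of a 5.6-fold higher number from compound 3 to compound 4 (0.74 log units; beyond the scatter). The estimate for compound 4 in this assay is 35 nM, with a range from 8 nM to 150 nM.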

Compound 4, half-maximal effective concentration: 72 nM
Compound 4: middle estimate off by 2.1-fold (0.31 log units), on the low side; low and high end bracket the measured number.
By their numbers in this assay, from the lowest: compound 3; then compounds 4, 1 and 2 (each within the scatter of the next, the first and the last beyond it).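

In this assay, among the compounds shown here, the earlier compounds compared tert-butyl only with groups that carry a benzene-type ring, so they could not show whether a small carbon group at this place would do as well, and the new result shows that this one does not: an 11-fold higher number from compound 3 to compound 4 (1.06 log units; beyond the scatter) is a large step. A small all-carbon group on this saturated chain carbon is therefore not enough to reproduce the low number of compound 3, and the ring-bearing groups are not alone in losing it, since a 2.4-fold lower number from compound 2 to compound 4 (0.38 log units; beyond the scatter) is only a modest step and a 1.4-fold lower number from compound 1 to compound 4 (0.15 log units; within the scatter) lies within the scatter, leaving cyclopropyl and 4-chlorophenyl indistinguishable here. Nothing available explains why tert-butyl stands apart from the other three groups.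

From the compounds shown here alone, what remains open is whether an isopropyl or a cyclobutyl group on the same chain carbon would give a number near that of compound 3 or near that of compound 4. Going by these compounds, it is also open whether a group holding an amine or a hydroxyl, rather than carbon alone, would be tolerated at this place.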